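The source may hold more compounds than are shown below. What is called first, only, known or untested is meant among the compounds shown, and "the series" means these compounds.

Of the compounds shown here, three have so far been measured in a physicochemical assay for lipophilicity, at pH 7.4; on this read-out higher numbers stand for higher lipophilicity and lower numbers for lower lipophilicity. Compound 1 (`COc1cccc(C(=O)NCc2c(C)cc(C)[nH]c2=O)c1F`) gives 1.4 as the lowest of the three numbers. The nearest is compound 3 (`Cc1cc(C)c(CNC(=O)c2cccc(OC(C)C)c2C)c(=O)[nH]1`) with 2.1 and the furthest is compound 2 (`Cc1cc(C)c(CN2CCc3c(Cl)cc(-c4cn[nH]c4)c(Cl)c3C2=O)c(=O)[nH]1`) with 3 on the same scale. Both gaps from compound 1 lie beyond the scatter of repeated measurements.

Compound 4 (`COc1cccc(C(=O)NCc2c(C)cc(C)[nH]c2=O)c1O`) has not yet been measured. It departs from compound 1 in one place: hydroxy in place of fluoro on an aromatic carbon on an aromatic carbon, ortho to a large group and ortho to a methoxy group. Among the measured compounds shown here, no two measured compounds differ in one place only, so the data hold no direct precedent for this exchange of fluoro for hydroxy. Any expectation therefore starts from compound 1 at 1.4 and rests on the structural change alone. A small downward step in this assay is expected, and it may well stay within the scatter. The expected move is a number 0.20 log units lower from compound 1 to compound 4 (within the scatter) on this reading. For compound 4 the estimated value is 1.2 with an expected range from 0.7 to 1.7 once it is measured.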

Compound 4, distribution coefficient: 1.9
For compound 4 the middle estimate is 0.70 log units below the measured one; the measured number lies above the stated range.
By their numbers in this assay, from the lowest: compound 1; then compounds 4 and 3 (each within the scatter of the next); then compound 2.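

In this assay the exchange of fluoro for hydroxy on an aromatic carbon, ortho to a large group and ortho to a methoxy group, gives a number 0.50 log units higher from compound 1 to compound 4 (beyond the scatter) and so provides the first direct reading of a single change among these compounds. It shows that this position is not silent on this read-out and that this one exchange, which brings in one hydrogen-bond donor and one hydrogen-bond acceptor where fluoro counted none, moves the number upward rather than downward. No measurement presented here accounts for the direction or size of this step.

Among the compounds shown here, with only one exchange seen at this carbon, it remains open where other groups, such as an amine, a carboxylic acid or a methyl group, would fall relative to fluoro and hydroxy. On these data alone, it also remains open whether fluoro and hydroxy would differ in the same direction and by a similar amount if the neighbouring methoxy group gave way to a longer chain such as ethoxy, or if the exchange were made on a different core.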